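Furyl Replaces Nitrophenyl: Expected Tolerance of Compound 4

This account rests on a few compounds, and the source may have more. Where it says the series, first, only, none or still open, it means among the compounds named here.

Measured in an ADME assay on MT4 cells (Homo sapiens) for cytotoxicity, read by MTT assay; a higher number here means that more compound is tolerated, a lower number that less compound is tolerated:
compound 1 `O=C1c2ccccc2C(=O)N1CCOC(=S)N(C(=O)c1ccccc1[N+](=O)[O-])c1ccc(Cl)cc1` gives 21000 nM
compound 2 `O=C1c2ccccc2C(=O)N1CCOC(=S)N(C(=O)c1ccc(Cl)cc1Cl)c1ccc(Cl)cc1` gives 18000 nM
compound 3 `O=C1c2ccccc2C(=O)N1CCOC(=S)N(C(=O)c1c(Cl)cccc1Cl)c1ccc(Cl)cc1` gives 20000 nM

Compound 1 is separated from its two neighbours only within the scatter: a 1.2-fold lower number from compound 1 to compound 2 (0.07 log units; within the scatter) and a 1.1-fold lower number from compound 1 to compound 3 (0.02 log units; within the scatter). Both of those steps swap the 2-nitrophenyl on the carbonyl carbon for a dichlorophenyl and leave the read-out essentially unchanged, as does a 1.1-fold higher number from compound 2 to compound 3 (0.05 log units; within the scatter).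

Compound 4 `Cc1cc(C(=O)N(C(=S)OCCN2C(=O)c3ccccc3C2=O)c2ccc(Cl)cc2)c(C)o1` differs from compound 1 by 2,5-dimethylfuran-3-yl in place of 2-nitrophenyl on a carbonyl carbon. The two steps from compound 1 bear directly on this exchange at the same carbonyl carbon, and neither moved the number beyond the scatter. No step beyond the scatter is therefore expected in this assay for compound 4; its estimate is 20000 nM, between 10000 nM and 40000 nM, corresponding to a 1.1-fold lower number from compound 1 to compound 4 (0.02 log units; within the scatter).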

Compound 4, half-maximal cytotoxic concentration: 40000 nM
For compound 4 the middle estimate is 2.0-fold (0.30 log units) below the measured one, within the range that was stated.
By their numbers in this assay, from the lowest: compounds 2, 3, 1 and 4 (each within the scatter of the next, the first and the last beyond it).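

In this assay, for the compounds shown here, the place on the carbonyl carbon takes 2,5-dimethylfuran-3-yl, a five-membered aromatic ring with 1 hetero atom, where the earlier compounds carried only six-membered aromatic rings of carbon. Two of the new steps, a 1.9-fold higher number from compound 1 to compound 4 (0.28 log units; within the scatter) and a 2.0-fold higher number from compound 3 to compound 4 (0.30 log units; within the scatter) stay within the scatter, whereas a 2.2-fold higher number from compound 2 to compound 4 (0.35 log units; beyond the scatter) is the only step among these compounds to pass beyond it, and only modestly. Nothing available here accounts for that step.

The compounds shown leave open what a furan without its two methyl groups would give at this carbonyl carbon. They also leave open whether an amine or a carboxylic acid there would keep the number in the same range.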